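Dichlorothiophene sulfonylurea on the dichlorobenzyl pyrazole core

The compounds below may be only part of what the source reports. "The series", "measured", "known", "first", "only" and "open" are said of these compounds alone.

Compound 1 `O=C(NS(=O)(=O)c1cc(Cl)c(Cl)s1)OC/C=C1\CCCc2cnn(Cc3ccc(Cl)cc3Cl)c21`: an assay on isolated protein for displacement of a labelled ligand from prostaglandin E2 receptor EP3 subtype (Homo sapiens), read by scintillation counting, with a stated time of 2 h (on this read-out lower numbers stand for stronger inhibition and higher numbers for weaker inhibition), compound 1 gives 1 nM
Compound 2 `Cc1nc(C)c(S(=O)(=O)NC(=O)NC/C=C2\CCCc3cnn(Cc4ccc(Cl)cc4Cl)c32)s1`: in this assay compound 2 gives 2 nM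
Compound 3 `O=C(NS(=O)(=O)c1ccc(Cl)cc1)OC/C=C1\CCCc2cnn(Cc3ccc(Cl)cc3Cl)c21`: in this assay compound 3 gives 11 nM

Among these three numbers compound 2 stands second highest. Its nearest neighbour is compound 1, whose number is within the usual scatter of that of compound 2; its furthest is compound 3, whose number lies beyond the scatter above it. Compound 4 `O=C(NC/C=C1\CCCc2cnn(Cc3ccc(Cl)cc3Cl)c21)NS(=O)(=O)c1cc(Cl)c(Cl)s1` differs from compound 2 only at the sulfonyl sulfur: 4,5-dichlorothiophen-2-yl in place of 2,4-dimethyl-1,3-thiazol-5-yl on a sulfonyl sulfur. For the measured compounds named here, the one measured step that touches the group on that sulfur is an 11-fold higher number from compound 1 to compound 3 (1.04 log units; beyond the scatter), where the dichlorothiophene ring gave the lower number. The dichlorothiophene ring entering compound 4 is the very ring carried by compound 1, whose value sits close to that of compound 2, so no step beyond the scatter is expected in this assay, if anything a move toward a slightly lower number. Compound 4 is therefore expected to give about 1.2 nM, within 0.4 nM to 4 nM, an estimated step of a 1.7-fold lower number from compound 2 to compound 4 (0.22 log units; within the scatter).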

Compound 4, inhibition constant: 0.5 nM
Compound 4: the middle estimate sits 2.4-fold (0.38 log units) above what was measured; measured number inside the range.
By their numbers in this assay, from the lowest: compounds 4, 1 and 2 (each within the scatter of the next, the first and the last beyond it); then compound 3.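

In this assay, replacing 2,4-dimethyl-1,3-thiazol-5-yl with 4,5-dichlorothiophen-2-yl on the sulfonyl sulfur gives a 4.0-fold lower number from compound 2 to compound 4 (0.60 log units; beyond the scatter). This shows that the group at this position still shifts the number at the low end of the range, even between two five-membered aromatic rings of equal heavy-atom count. The dichlorothiophene ring now gives the lower number in both measured steps at this position, the other being an 11-fold higher number from compound 1 to compound 3 (1.04 log units; beyond the scatter), against two different partner groups and in two different linkers. No evidence is available that explains this step.

The compounds shown leave open whether the gain depends on both chlorine atoms or on the thiophene ring itself, which an unsubstituted thiophen-2-yl or a 5-chlorothiophen-2-yl group on the same sulfur would help separate. They also leave open how 4-chlorophenyl would behave in the linker of compound 4.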